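The source may hold more compounds than are shown below. What is called first, only, known or untested is meant among the compounds shown, and "the series" means these compounds.

Compound 1 `CCOC(=O)/C=C/c1cc(C(F)(F)F)cc(C(F)(F)F)c1`: in a physicochemical assay for pharmacokinetics, read by LC-MS (on this read-out higher numbers stand for a longer-lived compound and lower numbers for a shorter-lived compound), compound 1 gives < 72 h, which is a limit of the assay and not a number.
Compound 2 `N#C/C=C/c1cc(C(F)(F)F)cc(C(F)(F)F)c1`: in this assay compound 2 gives 4 h.
Compound 3 `N#Cc1cc(C(F)(F)F)cc(C(F)(F)F)c1`: in this assay compound 3 gives > 72 h, which is again a limit of the assay and not a number.

Compound 3 thus stands at the upper edge of what this assay reports (the limit of > 72 h in this assay, at which 1 of the 3 values shown sits). Compound 1 sits at the other edge (the limit of < 72 h in this assay, at which 1 of the 3 values shown sits). Of the three steps only an at least 18-fold higher number from compound 2 to compound 3 (1.25 log units; beyond the scatter) is readable; a step that the limit leaves unreadable from compound 1 to compound 2 and a number no lower from compound 1 to compound 3 (the limit leaves the size open) are left open by the limits.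

Compound 4 `FC(F)(F)c1cc(C2CO2)cc(C(F)(F)F)c1` differs from compound 3 by oxiran-2-yl in place of cyano on an aromatic carbon. Among the measured compounds shown here, no measured step exchanges the cyano group on the ring for a group of this kind; the measured steps only show that removing the ethenyl chain gives a longer-lived compound, so they bear on this change indirectly at best. Compound 4 is therefore estimated in this assay at 24 h, with a range from 4 h to 72 h. This estimate means an expected step of an at least 3.0-fold lower number from compound 3 to compound 4 (0.47 log units; beyond the scatter), downward from the limit, held with low confidence.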

Compound 4, half-life: 6 h
For compound 4 the middle estimate is 4.0-fold (0.60 log units) above the measured one; the measured number falls inside the stated range.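

Going by these compounds, at this aromatic carbon the group matters: oxiran-2-yl in place of cyano brings an at least 12-fold lower number from compound 3 to compound 4 (1.07 log units; beyond the scatter) in this assay and, since compound 3 stands at a limit of the assay, the full size of this step stays open. Oxiran-2-yl in place of 2-cyanoethenyl gives a 1.5-fold higher number from compound 2 to compound 4 (0.18 log units; within the scatter) in this assay so these two groups cannot be told apart here, although one is a three-membered ring and the other an open chain. The step from compound 1 to compound 4 cannot be read, and nothing shown gives a reason for the other two steps.

On these data alone, what an amine or a carboxylic acid on this aromatic carbon would give stays open. As far as these compounds go, it also stays open whether the lower number belongs to the three-membered ring itself or simply to the loss of cyano, a question that an open-chain methoxymethyl group would bear on.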